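A few compounds are considered here, and "the series" means these few. Any claim that something is new, unique, unknown or untested is made for them only; others in the source may bear on it.

Measured in a functional assay on A549 cells (Homo sapiens) for inhibition, read by MTT assay, with a stated time of 48 h; a lower number here means a stronger inhibitor of growth, a higher number a weaker inhibitor of growth:
Compound 1 `COc1cc(C2=NN(C(=O)c3ccc(C)nc3)C(c3cn(C)c4ccccc34)C2)cc(OC)c1OC`: 230 nM
Compound 2 `COc1ccc2c(c1)c(C1CC(c3ccc(Br)cc3)=NN1C(=O)c1ccc(OC)nc1)cn2C`: > 10000 nM (a limit)

Compound 2 has no number of its own in this assay: its > 10000 nM is only a limit. Compound 1, at 230 nM, shows that a measurable value can be reached in this small set.

Compound 3 `COc1cccc(C2=NN(C(=O)c3ccc(OC)nc3)C(c3cn(C)c4ccc(OC)cc34)C2)c1`, not yet measured, has 3-methoxyphenyl in place of 4-bromophenyl on a carbon with a double bond to nitrogen. Among the measured compounds shown here, no measured step shows what such a change does, so any expectation here is loose. A modest gain in growth inhibition in this assay is expected, and the step is estimated as an at least 3.3-fold lower number from compound 2 to compound 3 (0.52 log units; beyond the scatter). It remains quite possible that the result will again be only a limit. For compound 3 the expected value is 3000 nM, with an estimated range of 400 nM to 12000 nM.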

Compound 3, concentration for 50% growth inhibition: 470 nM
Compound 3: the middle estimate sits 6.4-fold (0.81 log units) above what was measured, and the stated range covers the measured number.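

Putting 3-methoxyphenyl in place of 4-bromophenyl on a carbon with a double bond to nitrogen gives an at least 21-fold lower number from compound 2 to compound 3 (1.32 log units; beyond the scatter) in this assay. Among the compounds shown here, this is the first sign that the group at this place can decide whether a compound with the (6-methoxypyridin-3-yl)carbonyl group reaches a measurable value at all. The step gives only a lower bound on the change, since compound 2 has no number of its own: the limit of > 10000 nM in this assay, at which 1 of the 3 values shown sits.

The pair cannot separate the loss of the bromine from the arrival of the methoxy group, or from the shift of the substituent around the phenyl ring, since all of these come together in this one change. The compounds shown also leave open how an unsubstituted phenyl, an amine or a longer chain at this place would read.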